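Triazole-phthalimide series: removing the aryl ketone on a new core

The compounds below may be only part of what the source reports. "The series", "measured", "known", "first", "only" and "open" are said of these compounds alone.

Compound 1 `CCCc1nnc(SCC(=O)c2ccc(C)cc2)n1N1C(=O)c2ccccc2C1=O` in a functional assay on HepG2 cells (Homo sapiens) for cytotoxicity, read by MTT assay, with a stated time of 48 h (on this read-out higher numbers stand for weaker inhibition and lower numbers for stronger inhibition), reaches only the limit of > 200000 nM. Compound 2 `CCCc1nnc(SC)n1N1C(=O)c2ccccc2C1=O` likewise stops at the limit of > 200000 nM in this assay. The change between the two, (hydrogen in place of (4-methylphenyl)carbonyl on a saturated chain carbon bound to a sulfur), therefore gives a step that the two limits leave unreadable from compound 1 to compound 2, since both values sit at the limit of > 200000 nM in this assay, at which 2 of the 3 values shown sit.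

Among the compounds with values here, compound 3 `COc1cc(-c2nnc(SCC(=O)c3ccc(C)cc3)n2N2C(=O)c3ccccc3C2=O)cc(OC)c1OC` is the one member with a number: in this assay compound 3 gives 9440 nM. The cores of compound 1 and compound 3 differ by 3,4,5-trimethoxyphenyl in place of propyl on an aromatic carbon, and the step is an at least 21-fold lower number from compound 1 to compound 3 (1.32 log units; beyond the scatter).

Compound 4 `COc1cc(-c2nnc(SC)n2N2C(=O)c3ccccc3C2=O)cc(OC)c1OC` carries the same change as the first pair, (hydrogen in place of (4-methylphenyl)carbonyl on a saturated chain carbon bound to a sulfur), at the same place, but on the core of compound 3. The measured counterpart stays unreadable because of the limit of > 200000 nM in this assay, at which 2 of the 3 values shown sit, so the direction of the change is open; a loss of some size is the working assumption, with wide bounds.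

Compound 4 is expected at 30000 nM, with a range from 8000 nM to 150000 nM. The estimated step is a 3.2-fold higher number from compound 3 to compound 4 (0.50 log units; beyond the scatter), resting only on the value of compound 3 and on the unreadable first pair.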

Compound 4, half-maximal inhibitory concentration: > 200000 nM
Compound 4 gave a limit, no number; the forecaster's own chance of this, stated with the estimate: 30%; at least 6.6-fold (0.82 log units) between middle value and limit.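

In this assay, hydrogen in place of (4-methylphenyl)carbonyl on a saturated chain carbon bound to a sulfur gives an at least 21-fold higher number from compound 3 to compound 4 (1.32 log units; beyond the scatter), so on the core of compound 3 the change carries a large step towards weaker inhibition. In this assay, from the compounds shown here alone, compound 4 gives > 200000 nM, which is a limit and not a number, so the step shows only a minimum size and its true size stays unknown. The same change on the core of compound 1 cannot be read, so the series does not show that the step carries from one core to another, only that the core of compound 3 responds to the change: the limit of > 200000 nM in this assay, at which 3 of the 4 values shown sit.

The compounds shown leave open whether the carbonyl or the methylphenyl ring accounts for the step, since the two leave together. Also open, going by these compounds, is whether a benzyl group or a longer chain ending in an amine, on the same sulfur, would keep a measurable number on the core of compound 3.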